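Following the aryl swap from compound 3 to compound 4

The compounds below may be only part of what the source reports. "The series", "measured", "known", "first", "only" and "open" are said of these compounds alone.

Of the compounds shown here, three sharing one core have been measured in an ADME assay for permeability; on this read-out higher numbers stand for higher permeability and lower numbers for lower permeability. Compound 1 `CNC(=O)c1cc(C(=O)N[C@H]2CC[C@H](O)CC2)n([C@@H](C)c2cccc(Cl)c2)n1` gives 235 nm/s, compound 2 `CNC(=O)c1cc(C(=O)N[C@H]2CC[C@H](O)CC2)n([C@@H](C)c2ccccc2)n1` gives 80 nm/s, and compound 3 `CNC(=O)c1cc(C(=O)N[C@H]2CC[C@H](O)CC2)n([C@@H](C)c2ccccc2Cl)n1` gives 100 nm/s. Compound 3 thus stands second highest of the three numbers: the gap to compound 2 is within the scatter, while the step of a 2.4-fold lower number from compound 1 to compound 3 (0.37 log units; beyond the scatter) is beyond it. Compound 4 `CNC(=O)c1cc(C(=O)N[C@H]2CC[C@H](O)CC2)n([C@@H](C)c2ccc(C(F)(F)F)cc2)n1` is now to be measured in this assay. Its change from compound 3 is 4-(trifluoromethyl)phenyl in place of 2-chlorophenyl on a saturated chain carbon bound to an aromatic nitrogen and a saturated chain carbon. Among the compounds with values here, no measured step covers a trifluoromethyl group or this position, so only the neighbouring steps bear on it: a 2.9-fold lower number from compound 1 to compound 2 (0.47 log units; beyond the scatter) and a 2.4-fold lower number from compound 1 to compound 3 (0.37 log units; beyond the scatter) are modest, and a 1.3-fold higher number from compound 2 to compound 3 (0.10 log units; within the scatter) is within the scatter. The account therefore expects a step of roughly that size or smaller, a 1.6-fold higher number from compound 3 to compound 4 (0.20 log units; within the scatter), most likely upward but possibly none beyond the scatter. Compound 4 is estimated at 160 nm/s, within a range from 70 nm/s to 350 nm/s.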

Compound 4, apparent permeability in the ADME assay: 270 nm/s
Beside the measured number, compound 4's estimate is 1.7-fold (0.23 log units) below it; the range from low to high includes it.
By their numbers in the ADME assay, from the lowest: compounds 2 and 3 (each within the scatter of the next); then compounds 1 and 4 (each within the scatter of the next).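

In the ADME assay, 4-(trifluoromethyl)phenyl on this saturated chain carbon shows that a group other than chloro can also shift the number beyond the scatter, with a 3.4-fold higher number from compound 2 to compound 4 (0.53 log units; beyond the scatter) and a 2.7-fold higher number from compound 3 to compound 4 (0.43 log units; beyond the scatter), while a 1.1-fold higher number from compound 1 to compound 4 (0.06 log units; within the scatter) leaves compound 4 and compound 1 unseparated. In a physicochemical assay for solubility, measured as kinetic solubility (on this read-out lower numbers stand for lower solubility and higher numbers for higher solubility), compound 3 gives >= 182 ug/mL as its result, which is a limit. In the physicochemical assay compound 4 gives >= 175 ug/mL as its result, which is also a limit.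

The step between these two limits cannot be read, and nothing shown gives a cause for the steps in permeability. On these data alone, what an amine or a carboxylic acid on this aromatic ring would give in the ADME assay stays open, as does any readable difference in the physicochemical assay for this change.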